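The compounds below may be only part of what the source reports. "The series", "measured", "known", "first", "only" and "open" are said of these compounds alone.

Measured compounds:
compound 1, `CN(C)C1CCN(c2nccnc2OC2CN(c3ccc4ccccc4n3)C2)CC1`: 500000 nM
compound 2, `NC(=O)C1CCN(c2nccnc2OC2CN(c3ccc4ccccc4n3)C2)CC1`: 14000 nM
compound 3, `OCc1cccc(-c2nccnc2OC2CN(c3ccc4ccccc4n3)C2)c1`: 29000 nM

The three compounds share one core and differ only in the group attached to an aromatic carbon of that core. In a physicochemical assay for solubility, in phosphate buffer, at pH 7.4 (on this read-out higher numbers stand for higher solubility and lower numbers for lower solubility), compound 1 stands highest of the three: the step of a 36-fold lower number from compound 1 to compound 2 (1.55 log units; beyond the scatter) and the step of a 17-fold lower number from compound 1 to compound 3 (1.24 log units; beyond the scatter) both lead well downwards, while the step of a 2.1-fold higher number from compound 2 to compound 3 (0.32 log units; beyond the scatter) between the two lower compounds is a modest one.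

Compound 4, `c1ccc2nc(N3CC(Oc4nccnc4-c4ccc5scnc5c4)C3)ccc2c1`, is not yet measured. It differs from compound 1 in one place: 1,3-benzothiazol-5-yl in place of 4-(dimethylamino)piperidin-1-yl on an aromatic carbon. Both measured steps away from compound 1 bear on this change, since each alters or removes the 4-(dimethylamino)piperidin-1-yl group, and each produced a large fall in this assay. Compound 3 received a 3-(hydroxymethyl)phenyl group and fell by a 17-fold lower number from compound 1 to compound 3 (1.24 log units; beyond the scatter); compound 4 instead receives a 1,3-benzothiazol-5-yl group, so a fall of at least that size is expected, and probably a somewhat larger one. The step from compound 1 to compound 4 is therefore expected to be a 100-fold lower number from compound 1 to compound 4 (2.00 log units; beyond the scatter). Compound 4 is estimated at 5000 nM, within a range from 1000 nM to 25000 nM.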

Compound 4, solubility: < 1000 nM
Compound 4 ended at the assay's limit (the forecaster's own chance of this, stated with the estimate: 15%); middle value at least 5.0-fold (0.69 log units) away from the limit.
By their numbers in this assay, from the lowest: compound 2; then compound 3; then compound 1. At a limit, below all of these: compound 4.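

In this assay compound 4 gives < 1000 nM, which is a limit of the assay and not a number: the limit of < 1000 nM in this assay, at which 1 of the 4 values shown sits. Even so, every step to it is large and beyond the scatter: an at least 500-fold lower number from compound 1 to compound 4 (2.69 log units; beyond the scatter), an at least 29-fold lower number from compound 3 to compound 4 (1.46 log units; beyond the scatter), and an at least 14-fold lower number from compound 2 to compound 4 (1.14 log units; beyond the scatter). The earlier compounds shown here showed that the read-out at this position, an aromatic carbon next to the ring nitrogen, can fall when 4-(dimethylamino)piperidin-1-yl is replaced, and compound 4 now adds that 1,3-benzothiazol-5-yl ends lowest of the four, even though it has the same counts of heavy atoms, hydrogen-bond donors and hydrogen-bond acceptors as the group it replaces, so those counts alone do not set the number for this pair.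

On these data alone, how far compound 4 really lies past its limit stays open, and so does the question of whether the dimethylamino group itself carries the high number of compound 1. A 1,3-benzothiazol-5-yl bearing a dimethylaminomethyl chain, or a piperidine bearing a carboxylic acid in place of the carbamoyl of compound 2, would speak to that second question.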